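Aryl swap on the sulfonyl group of compound 2

This account rests on a few compounds, and the source may have more. Where it says the series, first, only, none or still open, it means among the compounds named here.

Two compounds have been run in an assay on isolated protein for displacement of a labelled ligand from metabotropic glutamate receptor 5 (Homo sapiens), with a stated time of 60 min, tested at 1 uM; on this read-out lower numbers stand for less inhibition and higher numbers for more inhibition at the one concentration tested (going by the name of the read-out). Compound 1 `O=S(=O)(c1cccc(F)c1)c1cnc2cc(Cl)ccc2c1N1CCC(CO)CC1` gives 71%. Compound 2 `COc1ccc2ncc(S(=O)(=O)c3cccc(C#N)c3)c(N3CCC(C)CC3)c2c1` gives 90%, the higher of the two numbers, and its gap to compound 1 lies beyond the usual scatter. Compound 3 `COc1ccc2ncc(S(=O)(=O)c3ccc(C)c(F)c3)c(N3CCC(C)CC3)c2c1` is not yet measured; it carries 3-fluoro-4-methylphenyl in place of 3-cyanophenyl on a sulfonyl sulfur. Going by the values given here, no measured pair shows this change, so nothing in the set fixes its size. A step of a number 6 percentage points lower from compound 2 to compound 3 (within the scatter) in this assay is expected, downward if anything and not clearly beyond the scatter. The estimate for compound 3 is 84%, within 65% to 97%.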

Compound 3, a percentage reported as inhibition, at one concentration (the size of the read-out at that concentration, not a potency): 73%
For compound 3 the middle estimate is 11 percentage points above the measured one, within the range that was stated.
By their numbers in this assay, from the lowest: compounds 1 and 3 (each within the scatter of the next); then compound 2.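

Going by these compounds alone, this gives the first comparison in this assay that differs in one place only: on a sulfonyl sulfur, 3-fluoro-4-methylphenyl in place of 3-cyanophenyl gives a number 17 percentage points lower from compound 2 to compound 3 (beyond the scatter). The read-out therefore responds to this aryl group with the rest of the molecule unchanged, and the number is higher with 3-cyanophenyl than with 3-fluoro-4-methylphenyl. No measurement in hand bears on the reason for this step.

On these data alone, the swap changes the aryl substituents together, so their separate contributions remain open. Unsubstituted phenyl or a pyridyl group at the same place would show whether the inhibition in this assay is higher, lower or level with other aryl groups.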